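Methyl for nitro on the benzyl ether of compound 2

The source may hold more compounds than are shown below. What is called first, only, known or untested is meant among the compounds shown, and "the series" means these compounds.

Compound 1 `O=c1c(O)c(-c2ccccc2)oc2cc(OCc3ccccc3Cl)cc(O)c12` gives only a limit in an ADME assay on Huh-5-2 cells (Homo sapiens) for cytotoxicity, read by WST assay, with a stated time of 3 days (on this read-out higher numbers stand for lower toxicity in this test and lower numbers for higher toxicity in this test), namely > 100000 nM. Among the measured compounds shown here, compound 2 `O=c1c(O)c(-c2ccccc2)oc2cc(OCc3ccc([N+](=O)[O-])cc3)cc(O)c12` gives 93000 nM in this assay, the only full number so far. The step of an at least 1.0-fold lower number from compound 1 to compound 2 (0.03 log units; that floor lies within the scatter) lies within the scatter, and its size is bounded by the limit of > 100000 nM in this assay, at which 1 of the 2 values shown sits. Compound 3 `Cc1ccc(COc2cc(O)c3c(=O)c(O)c(-c4ccccc4)oc3c2)cc1` differs from compound 2 by methyl in place of nitro on an aromatic carbon. For the measured compounds named here, the only measured step that bears on this position is an at least 1.0-fold lower number from compound 1 to compound 2 (0.03 log units; that floor lies within the scatter), which also swapped the group on the benzyl ether and produced no change beyond the scatter. No step beyond the scatter is therefore expected for a 1.1-fold higher number from compound 2 to compound 3 (0.03 log units; within the scatter) in this assay. Compound 3 is estimated at 100000 nM in this assay, with a range from 40000 nM to 250000 nM, and a limit rather than a number is a real possibility.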

Compound 3, half-maximal cytotoxic concentration: 88000 nM
Estimate against measurement, compound 3: 1.1-fold (0.06 log units) above; the measured number falls inside the stated range.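

Among the compounds shown here, the first step between two full numbers, a 1.1-fold lower number from compound 2 to compound 3 (0.02 log units; within the scatter) in this assay, stays inside the scatter, so this read-out does not separate nitro from methyl at this place, para to a large group. The other new step, an at least 1.1-fold lower number from compound 1 to compound 3 (0.05 log units; that floor lies within the scatter), adds only a floor that also lies within the scatter, and it sets 4-methylphenyl against 2-chlorophenyl. Its true size stays open on one side, as compound 1 carries a limit and not a number: the limit of > 100000 nM in this assay, at which 1 of the 3 values shown sits.

From the compounds shown here alone, what an amine, a carboxylic acid or a longer chain at this place would do in this assay remains open. Going by these compounds, all three compounds share one core, so the part that core plays in this read-out, as against the benzyl ether, also remains open.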